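Bromo to Methyl on a Scaffold Without Measured Activity

This account rests on a few compounds, and the source may have more. Where it says the series, first, only, none or still open, it means among the compounds named here.

Measured compounds:
- compound 1 `Cc1ccc(S(=O)(=O)Oc2ccc3c(c2C)[C@H](Cn2cc(-c4ccc(Br)cc4)nn2)[C@@]24CC(=O)[C@@](C)(CC[C@@H]32)C4)cc1`: in a functional assay on HL-60 cells (Homo sapiens) for cytotoxicity, read by MTT assay, with a stated time of 4 days (a higher number here means a weaker inhibitor, a lower number a stronger inhibitor), compound 1 gives > 20000 nM, a limit of the assay.
- compound 2 `Cc1c(O)ccc2c1[C@H](Cn1cc(-c3ccccn3)nn1)[C@@]13CC(=O)[C@@](C)(CC[C@@H]21)C3`: compound 2 gives > 20000 nM, a limit.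
- compound 3 `C=C1C[C@]23C[C@@]1(O)CC[C@H]2c1ccc(O)c(C)c1[C@@H]3Cn1cc(-c2ccc(F)cc2)nn1`: compound 3 gives > 20000 nM, a limit.

None of the three compounds reached a numerical value in this assay. Going by the values given here, compound 1 therefore stands at the same place as the other two, described only by the limit of > 20000 nM in this assay, at which 3 of the 3 values shown sit, so no step between measured compounds can be sized, and no compound can be called stronger or weaker than another.

Compound 4 `Cc1ccc(-c2cn(C[C@H]3c4c(ccc(OS(=O)(=O)c5ccc(C)cc5)c4C)[C@@H]4CC[C@@]5(C)C[C@]43CC5=O)nn2)cc1` is the untested member. It differs from compound 1 in a single spot: methyl in place of bromo on an aromatic carbon. The rest of the shared core, including the sulfonate ester and the triazole, is unchanged.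

With every measured value sitting at the limit, and with a change this small in methyl in place of bromo on an aromatic carbon, no step beyond the scatter in this assay is expected from compound 1 to compound 4, and the most likely outcome is that compound 4 again returns only a limit. Compound 4 is estimated at 30000 nM, with a range of 10000 nM to 100000 nM, meaning an expected step that the limit leaves unreadable from compound 1 to compound 4.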

Compound 4, half-maximal inhibitory concentration: > 20000 nM
Compound 4: only a limit was reported (the forecaster's own chance of this, stated with the estimate: 85%); the middle value does not contradict the limit.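

No step can be read between compound 1 and compound 4, because each gives only a limit of the assay: the limit of > 20000 nM in this assay, at which 4 of the 4 values shown sit.

The compounds shown leave open whether any close relative of the shared core reaches a real number in this assay, and so whether methyl in place of bromo changes anything.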